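This account rests on a few compounds, and the source may have more. Where it says the series, first, only, none or still open, it means among the compounds named here.

Of the compounds shown here, two that share one core have been tested in a functional assay on KB cells (Homo sapiens) for cytotoxicity; on this read-out higher numbers stand for weaker inhibition and lower numbers for stronger inhibition. Compound 1 `NC(=S)c1cn(COCCO)c2ncnc(N)c12` carries a 2-hydroxyethyl chain on its core; in this assay compound 1 gives 115000 nM. Compound 2 `Cc1cccc(Cn2cc(C(=N)S)c3c(N)ncnc32)c1` carries a methylbenzyl group instead; in this assay compound 2 gives 30000 nM. Among the compounds with values here, of these two numbers, the one for compound 1 is the higher, and its gap to compound 2 lies beyond the usual scatter, so compound 1 is the weaker inhibitor of the pair.

Compound 3 `COCCOCn1cc(C(N)=S)c2c(N)ncnc21` has not yet been measured. The change from compound 1 to compound 3 is methyl in place of hydrogen on an oxygen on a saturated carbon.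

Within the data shown here, no pair of measured compounds shows this change, so there is nothing here to anchor its effect. The step is expected to be small, a 1.2-fold lower number from compound 1 to compound 3 (0.06 log units; within the scatter), and not beyond the scatter in either direction. Compound 3 is therefore expected to give about 100000 nM in this assay, with a range from 40000 nM to 250000 nM.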

Compound 3, half-maximal inhibitory concentration: 183000 nM
Beside the measured number, compound 3's estimate is 1.8-fold (0.26 log units) below it; measured number inside the range.
By their numbers in this assay, from the lowest: compound 2; then compounds 1 and 3 (each within the scatter of the next).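

Measured in this assay the change from 2-hydroxyethyl to 2-methoxyethyl gives a 1.6-fold higher number from compound 1 to compound 3 (0.20 log units; within the scatter) and this step lies within the usual scatter of repeated measurements. Within the data shown here, this is the first direct look at this position: on this oxygen on a saturated carbon, a methyl can take the place of the hydrogen with no change that this read-out can tell apart from scatter. Nothing measured here offers a reason for this result.

Going by these compounds, whether an amine or a carboxylic acid in place of the hydroxy group, or a longer chain, would move the number beyond the scatter remains open. Compound 2 differs from compound 3 in more than one place, so the pair cannot show what caused the gap between their numbers.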